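The source may report more compounds than this note shows. Statements on the series, on what has been measured and on what is new or still open speak of the compounds shown alone.

Measured compounds:
compound 1 `CC(=O)c1ccc(NC(=O)C(CC(C)C)N(C(=O)c2ccccc2)S(=O)(=O)c2ccc([N+](=O)[O-])cc2)cc1`: 8400000 nM in a functional assay, read by spectrophotometry, with a stated time of 20 min; a higher number here means a weaker inhibitor, a lower number a stronger inhibitor
compound 2 `CC(=O)c1ccc(NC(=O)C(C(C)C)N(C(=O)c2ccccc2)S(=O)(=O)c2ccc([N+](=O)[O-])cc2)cc1`: 6800000 nM in this assay

Compound 1 carries the higher of the two numbers, but compound 2 lies within the scatter of it, a 1.2-fold lower number from compound 1 to compound 2 (0.09 log units; within the scatter), so no order between the two can be read. That single step alters the chain on the saturated carbon bound to the amide-type nitrogen and leaves the sulfonyl aryl group untouched.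

Compound 3 `CC(=O)c1ccc(NC(=O)C(CC(C)C)N(C(=O)c2ccccc2)S(=O)(=O)c2ccccc2)cc1` differs from compound 1 by hydrogen in place of nitro on an aromatic carbon. Among the measured compounds shown here, no measured step touches this position, so nothing measured bears on the change directly. For the measured compounds named here, both measured compounds sit at very weak inhibition, and the one change tried left the number within the scatter. The expectation for compound 3 is therefore a number near that of compound 1, a 1.2-fold higher number from compound 1 to compound 3 (0.08 log units; within the scatter), with wide uncertainty. Compound 3 is estimated at 10000000 nM in this assay, with a range from 3000000 nM to 40000000 nM.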

Compound 3, half-maximal inhibitory concentration: 3200000 nM
Compound 3: the middle estimate sits 3.1-fold (0.49 log units) above what was measured, within the range that was stated.
By their numbers in this assay, from the lowest: compound 3; then compounds 2 and 1 (each within the scatter of the next).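

Unlike the chain change, which stayed within the scatter, the sulfonyl aryl group gives a readable response: hydrogen in place of nitro gives a 2.6-fold lower number from compound 1 to compound 3 (0.42 log units; beyond the scatter) in this assay. The nitro group is therefore not needed for the inhibition seen at this level, and the phenylsulfonyl compound is the stronger inhibitor of the pair, although the step is modest and compound 3 still has a very high number. Nothing available explains the step.

A single substituent pair cannot separate an effect of losing nitro from a general preference for hydrogen at this aromatic carbon, so an amine, a methoxy group or a chlorine atom there remains an open comparison. Also open, as far as these compounds go, is whether isopropyl in place of isobutyl would behave the same way with phenylsulfonyl as with (4-nitrophenyl)sulfonyl.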